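Aryl amine variation on the shared core

The source may hold more compounds than are shown below. What is called first, only, known or untested is meant among the compounds shown, and "the series" means these compounds.

Measured compounds:
compound 1 `C#CCSc1nc(NCCC#N)c2ccncc2n1`: > 80000 nM
compound 2 `C#CCSc1nc(Nc2ccc(Cl)cc2)c2ccncc2n1`: 16400 nM

In a functional assay on MGC-803 cells (Homo sapiens) for inhibition, read by MTT assay, with a stated time of 72 h (on this read-out higher numbers stand for weaker inhibition and lower numbers for stronger inhibition), compound 1 reports only a limit, > 80000 nM, which is the limit of > 80000 nM in this assay, at which 1 of the 2 values shown sits. Compound 2 gives 16400 nM, the only plain number shown in this assay. an at least 4.8-fold lower number from compound 1 to compound 2 (0.68 log units; beyond the scatter). Compound 3 `C#CCSc1nc(Nc2ccccc2O)c2ccncc2n1` differs from compound 2 by 2-hydroxyphenyl in place of 4-chlorophenyl on a nitrogen on an aromatic ring. Within the data shown here, the one measured step exchanges an alkyl chain for an aryl ring and does not bear on an exchange of one aryl ring for another; no step beyond the scatter is therefore expected in this assay. Compound 3 is estimated at 20000 nM, between 6000 nM and 60000 nM. This expectation amounts to a 1.2-fold higher number from compound 2 to compound 3 (0.09 log units; within the scatter).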

Compound 3, half-maximal inhibitory concentration: 21000 nM
Estimate against measurement, compound 3: 1.1-fold (0.02 log units) below; measured number inside the range.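

In this assay, exchanging one aryl ring for another on this nitrogen separates nothing: a 1.3-fold higher number from compound 2 to compound 3 (0.11 log units; within the scatter). The advantage over 2-cyanoethyl is not confined to 4-chlorophenyl, since 2-hydroxyphenyl, which brings a hydrogen-bond donor and acceptor, also gives an at least 3.8-fold lower number from compound 1 to compound 3 (0.58 log units; beyond the scatter). That step rests on a value of compound 1 that is only a limit: the limit of > 80000 nM in this assay, at which 1 of the 3 values shown sits.

Still open, from the compounds shown here alone, is whether a benzyl group or a plain alkyl chain without the nitrile on this nitrogen stays at the level of the aryl compounds. Going by these compounds, whether any substituted phenyl ring falls clearly below that level also remains open.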